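From Methoxy to Hydroxy: Estimating Compound 3

This account rests on a few compounds, and the source may have more. Where it says the series, first, only, none or still open, it means among the compounds named here.

Measured in a functional assay on HepG2 cells (Homo sapiens) for antiproliferative activity, read by sulforhodamine B assay, with a stated time of 48 h; a lower number here means a stronger inhibitor, a higher number a weaker inhibitor:
- Compound 1 `COc1ccc(/C=C/C(=O)c2ccccc2-c2ccc(F)cc2)cc1O`: 23 nM
- Compound 2 `COc1ccc(/C=C/C(=O)c2ccccc2-c2cccc(F)c2)cc1OC`: 150 nM

Of these two numbers, compound 2 has the higher, at 150 nM, and the gap to compound 1 lies beyond the scatter. Compound 2 therefore stands as the weaker inhibitor of the pair in this assay.

The next compound, compound 3 `COc1ccc(/C=C/C(=O)c2ccccc2-c2cccc(F)c2)cc1O`, comes from compound 2 by one change: hydrogen in place of methyl on an oxygen on an aromatic ring. In words, hydrogen takes the place of methyl on an oxygen on an aromatic ring, turning methoxy to hydroxy.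

Among the compounds with values here, no measured pair isolates this change, so the expectation is indirect. The hydroxy group that enters compound 3 is also present in compound 1, which gives 23 nM. On that single comparison, the number is expected to fall by a step beyond the scatter, towards a stronger inhibitor. The expected change is a 3.8-fold lower number from compound 2 to compound 3 (0.57 log units; beyond the scatter).

For compound 3 the estimated value is 40 nM, with an expected range of 12 nM to 120 nM.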

Compound 3, half-maximal inhibitory concentration: 8 nM
Estimate against measurement, compound 3: 5.0-fold (0.70 log units) above; measured number outside the range, below it.
By their numbers in this assay, from the lowest: compound 3; then compound 1; then compound 2.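

In this assay, hydrogen in place of methyl on an oxygen on an aromatic ring gives a 19-fold lower number from compound 2 to compound 3 (1.27 log units; beyond the scatter), so this pair reads the methoxy to hydroxy change directly, with nothing else altered, and shows it to be a large gain at this position. The second pair holds the hydroxy group fixed and reads a different place: 3-fluorophenyl in place of 4-fluorophenyl on an aromatic carbon gives a 2.9-fold lower number from compound 1 to compound 3 (0.46 log units; beyond the scatter), a modest step, but still one beyond the scatter, so the place of the fluorine also matters in this series. No supporting measurement accompanies these results that would account for the size of either step.

From the compounds shown here alone, each step rests on a single pair, so it remains open whether the methoxy to hydroxy change would give a step of similar size in a compound carrying 4-fluorophenyl. The compounds shown also leave open how an amine in place of the hydroxy, or an ethyl group in place of the hydrogen on that oxygen, would read in this assay.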